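The source may report more compounds than this note shows. Statements on the series, on what has been measured and on what is new or still open speak of the compounds shown alone.

Of the compounds shown here, two have so far been tested in a functional assay on MDA-MB-231 cells (Homo sapiens) for cytotoxicity, read by MTT assay, with a stated time of 48 h; on this read-out higher numbers stand for an effect only at larger amounts of compound and lower numbers for an effect already at smaller amounts. Compound 1 `CO[C@H]1O[C@H](COc2ccc(OC3CCCCC3)cc2)[C@@H](O)[C@H](O)[C@H]1Oc1ccc(C(C)C)cc1` gives 25000 nM. Compound 2 `CO[C@H]1O[C@H](COc2ccc(-c3ccccc3)cc2)[C@@H](O)[C@H](O)[C@H]1Oc1ccccc1C(C)C` gives 34000 nM, the highest of the two numbers, yet its nearest neighbour, compound 1, lies within the usual scatter of it, so the two cannot be told apart on these numbers. Compound 3 `CO[C@H]1O[C@H](COc2ccc(-c3ccccc3)cc2)[C@@H](O)[C@H](O)[C@H]1Oc1ccc(C(C)C)cc1` has not yet been measured. It differs from compound 2 in one place: 4-isopropylphenyl in place of 2-isopropylphenyl on an oxygen on a saturated carbon. Compound 1 already carries the 4-isopropylphenyl group and gives 25000 nM, a number close to that of compound 2, so this change on its own shows no sign of a large effect. The expectation for compound 3 is therefore a step of a 1.2-fold lower number from compound 2 to compound 3 (0.08 log units; within the scatter) that stays within the scatter, in no clear direction. Compound 3 is expected to give about 28000 nM, with a range from 12000 nM to 65000 nM.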

Compound 3, half-maximal effective concentration: 31000 nM
Estimate against measurement, compound 3: 1.1-fold (0.04 log units) below, and the stated range covers the measured number.
By their numbers in this assay, from the lowest: compounds 1, 3 and 2 (each within the scatter of the next).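

In this assay, 4-isopropylphenyl in place of 2-isopropylphenyl on the oxygen gives a 1.1-fold lower number from compound 2 to compound 3 (0.04 log units; within the scatter) and so, for this pair, the place of the isopropyl group on that ring makes no difference that can be read. The other end of the molecule can now be compared directly as well: phenyl in place of cyclohexyloxy on an aromatic carbon gives a 1.2-fold higher number from compound 1 to compound 3 (0.09 log units; within the scatter) and this is also no readable difference. Nothing measured here bears on these results.

The compounds shown leave open whether a group carrying an amine or a carboxylic acid, in place of the isopropylphenyl on that oxygen, would shift the number beyond the scatter. The same question stands for a longer chain in place of the phenyl on the aromatic carbon.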